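The source may report more compounds than this note shows. Statements on the series, on what has been measured and on what is new or still open speak of the compounds shown alone.

Among the measured compounds shown here, in an assay on isolated protein for binding affinity to 5-hydroxytryptamine receptor 7 (Rattus norvegicus) (on this read-out higher numbers stand for weaker inhibition and lower numbers for stronger inhibition), compound 2 `COc1ccccc1N1CCN(CCCCC(=O)c2cccc(O)c2)CC1` gives 15 nM, the lowest of the two numbers measured so far. Compound 1 `COc1cccc(C(=O)CCCN2CCN(c3ccccc3OC)CC2)c1` gives 109 nM in this assay, a gap that lies beyond the scatter. Compound 3 `COc1ccccc1N1CCN(CCCCC(=O)c2ccc(O)cc2)CC1` differs from compound 2 in one place: 4-hydroxyphenyl in place of 3-hydroxyphenyl on a carbonyl carbon. For the measured compounds named here, no step between measured compounds is available to calibrate a moved hydroxyl, so the expectation rests on compound 2 alone. For compound 3 the expected step is a 2.0-fold higher number from compound 2 to compound 3 (0.30 log units; within the scatter), which may sit within the scatter or lean toward a weaker number. Compound 3 is estimated at 30 nM, within 8 nM to 120 nM.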

Compound 3, inhibition constant: 59.1 nM
Compound 3: middle estimate off by 2.0-fold (0.29 log units), on the low side; low and high end bracket the measured number.
By their numbers in this assay, from the lowest: compound 2; then compounds 3 and 1 (each within the scatter of the next).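

Exchanging 3-hydroxyphenyl for 4-hydroxyphenyl on a carbonyl carbon gives a 3.9-fold higher number from compound 2 to compound 3 (0.60 log units; beyond the scatter) in this assay so the number at this position depends on where the hydroxyl sits, even though the two compounds have the same atoms. Compounds 1 and 2 differ in more than one place and could not isolate this change. Going by these compounds, whether an amine or a carboxylic acid in place of the hydroxyl would hold the number of compound 2 stays open, as does the outcome with a longer chain. Nothing shown here accounts for the size of this step.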